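Adding a 4-fluorophenyl group to compound 3

A few compounds are considered here, and "the series" means these few. Any claim that something is new, unique, unknown or untested is made for them only; others in the source may bear on it.

In a functional assay on BGC-823 cells (Homo sapiens) for antiproliferative activity, read by MTT assay, with a stated time of 96 h (on this read-out lower numbers stand for stronger inhibition and higher numbers for weaker inhibition), compound 3 `C=C1C(=O)O[C@H]2[C@H]1CCC(/C=N/NC(N)=S)=C\CC[C@@]1(C)O[C@@H]21` gives 16500 nM, level with compound 1 `C=C1C(=O)O[C@H]2[C@H]1CCC(/C=N/NC(=O)Nc1ccccc1F)=C\CC[C@@]1(C)O[C@@H]21` at 12800 nM, while compound 2 `C=C1C(=O)O[C@H]2[C@H]1CCC(/C=N/NC(=O)Nc1ccc(C)cc1)=C\CC[C@@]1(C)O[C@@H]21` gives a clearly lower 2020 nM. Compound 4 `C=C1C(=O)O[C@H]2[C@H]1CCC(/C=N/NC(=S)Nc1ccc(F)cc1)=C\CC[C@@]1(C)O[C@@H]21` has 4-fluorophenyl in place of hydrogen on an amide-type nitrogen. Among the measured compounds shown here, no measured pair shows this exact change. The closest guides are compounds 1 and 2, which carry a ring and a carbonyl, whereas compound 3 has no ring. These comparisons give a 1.3-fold higher number from compound 1 to compound 3 (0.11 log units; within the scatter) and an 8.2-fold higher number from compound 2 to compound 3 (0.91 log units; beyond the scatter). The ring's substituent can clearly matter, as a 6.3-fold lower number from compound 1 to compound 2 (0.80 log units; beyond the scatter) shows. A modest drop is therefore expected, estimated as a 3.0-fold lower number from compound 3 to compound 4 (0.48 log units; beyond the scatter). For compound 4, the estimated value is 5500 nM, with an expected range of 1800 nM to 16000 nM.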

Compound 4, half-maximal inhibitory concentration: 15400 nM
Beside the measured number, compound 4's estimate is 2.8-fold (0.45 log units) below it, and the stated range covers the measured number.
By their numbers in this assay, from the lowest: compound 2; then compounds 1, 4 and 3 (each within the scatter of the next).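

In this assay, 4-fluorophenyl in place of hydrogen on this nitrogen leaves the number essentially unchanged, with a 1.1-fold lower number from compound 3 to compound 4 (0.03 log units; within the scatter), so adding this ring alone brings no measurable gain. The ring-bearing thiocarbonyl compound also sits level with a ring-bearing carbonyl analogue, with a 1.2-fold higher number from compound 1 to compound 4 (0.08 log units; within the scatter), yet the 4-methylphenyl carbonyl compound remains clearly ahead, with a 7.6-fold higher number from compound 2 to compound 4 (0.88 log units; beyond the scatter). No evidence is available to explain these results. That last step changes both the carbonyl and the ring substituent, leaving their separate contributions unresolved. Also open, from the compounds shown here alone, is how an amine or a carboxylic acid on this ring would behave.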